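Cytotoxicity notes on a shared-core series

This account rests on a few compounds, and the source may have more. Where it says the series, first, only, none or still open, it means among the compounds named here.

Measured so far in an ADME assay on J774.A1 cells (Mus musculus) for cytotoxicity, read by MTT assay, with a stated time of 72 h; a lower number here means that less compound is tolerated, a higher number that more compound is tolerated:
compound 1, `CC1(c2ccc(Nc3nc(N4CCCc5ccccc54)nc(N4CCCc5ccccc54)n3)cc2)NC(=O)c2ccccc2N1`: "not determined" (no result reported).
compound 2, `CC1(c2ccc(NC(c3ccc(Cl)cc3)c3nnnn3C(C)(C)C)cc2)NC(=O)c2ccccc2N1`: > 400000 nM.
compound 3, `CC1(c2ccc(Nc3nc(N4CCc5ccccc5C4)nc(N4CCc5ccccc5C4)n3)cc2)NC(=O)c2ccccc2N1`: > 400000 nM.

For compound 3 the figure in this assay is a limit of the assay, not a number. For compound 2 the figure in this assay is likewise a limit. Compound 1 has no result in this assay. Compound 2 therefore stands at the limit of > 400000 nM in this assay, at which 2 of the 3 values shown sit, and no single number places it above or below any other compound in the series. Within the data shown here, with no numbers on either side, no step between measured compounds can be drawn.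

Compound 4, `COc1ccc(C(Nc2ccc(C3(C)NC(=O)c4ccccc4N3)cc2)c2nnnn2C(C)(C)C)cc1`, is not yet measured in this assay. It differs from compound 2 in one place: methoxy in place of chloro on an aromatic carbon

Among the measured compounds shown here, since the measured values here are limits only, there is no measured step to carry over to compound 4. The expected step of a number no higher from compound 2 to compound 4 (the limit leaves the size open) is none beyond the usual scatter, and the likeliest report is once more a limit rather than a number. For compound 4 the estimate in this assay is 400000 nM, expected to fall between 200000 nM and 800000 nM.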

Compound 4, half-maximal cytotoxic concentration: > 400000 nM
Compound 4 was reported as a limit; the forecaster's own chance of this, stated with the estimate: 85%; the middle value lies on the limit itself.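

Compound 2 and compound 4 both give only a limit in this assay, so no step can be read between them for the change from 4-chlorophenyl to 4-methoxyphenyl. Compound 2 stays where it stood: the limit of > 400000 nM in this assay, at which 3 of the 4 values shown sit.

The compounds shown leave open whether this change alters cytotoxicity at all, and how far any tolerated concentration lies past the limit.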